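Selenium-bearing fused bicyclic amines: cytotoxicity on a colon line

The source may hold more compounds than are shown below. What is called first, only, known or untested is meant among the compounds shown, and "the series" means these compounds.

Measured so far:
compound 1 `C[Se]c1nc(N)c2ccccc2n1` — 74800 nM
compound 2 `CCCCC[Se]c1nc([Se]CCCCC)c2ccccc2n1` — > 100000 nM
compound 3 `[SeH]c1nc(NCc2ccccc2)c2cccnc2n1` — 33100 nM

The read-out throughout is a functional assay on HT-29 cells (Homo sapiens) for cytotoxicity, read by MTT assay, with a stated time of 72 h; on this read-out lower numbers stand for stronger inhibition of growth and higher numbers for weaker inhibition of growth. Compound 1 gives 74800 nM in this assay. Compound 3 , on a different core, gives 33100 nM. For compound 2 the entry is a limit of the assay, not a number, at the limit of > 100000 nM in this assay, at which 1 of the 3 values shown sits; compound 2 therefore stands at the weak end of the three.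

Compound 4 `CCCCC[Se]c1nc(NCc2ccccc2)c2ccccc2n1` is not yet measured. It differs from compound 2 by a group of 8 heavy atoms (7 carbon, 1 nitrogen; one six-membered aromatic ring of carbon only) in place of a group of 6 heavy atoms (5 carbon, 1 selenium; no ring), on an aromatic carbon; the entering group is a benzylamino, the leaving one a chain of carbons bound to selenium. For the measured compounds named here, no step between measured compounds is available, so the size of the expected step rests on compound 2 alone and on the benzylamino compound 3 with its 33100 nM. A step from compound 2 to compound 4 toward stronger inhibition is expected, estimated as an at least 2.5-fold lower number from compound 2 to compound 4 (0.39 log units; beyond the scatter). Compound 4 is estimated at 40000 nM, with a range from 15000 nM to 100000 nM.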

Compound 4, concentration for total growth inhibition: > 100000 nM
Compound 4 ended at the assay's limit; the forecaster's own chance of this, stated with the estimate: 20%; middle value at least 2.5-fold (0.39 log units) away from the limit.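

In this assay compound 2 and compound 4 both sit at a limit of the assay, so no step between them can be read: the limit of > 100000 nM in this assay, at which 2 of the 4 values shown sit.

As far as these compounds go, how far either compound lies beyond that limit, and so what the benzylamino group changes on the shared core, stays open.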